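The source may report more compounds than this note shows. Statements on the series, on what has been measured and on what is new or still open speak of the compounds shown alone.

Compound 1 `CCCOC(=O)C1=C(C)NC(=O)NC1c1cccs1`: 32%
Compound 2 `CCC(C)OC(=O)C1=C(C)NC(=O)NC1c1ccoc1`: 11%

In an assay on membranes from HeLa cells for displacement of a labelled ligand from adenosine receptor A3 (Homo sapiens), read by scintillation counting, with a stated time of 180 min, tested at 1 uM (a higher number here means more inhibition at the concentration tested (going by the name of the read-out), a lower number less inhibition), compound 2 stands lowest of the two readings; compound 1 sits higher by a gap beyond the usual scatter. Compound 3 `CCC(C)OC(=O)C1=C(C)NC(=O)NC1c1cccs1` is not yet measured. From compound 2 to compound 3 the change is thiophen-2-yl in place of furan-3-yl on a saturated ring carbon. For the measured compounds named here, no measured pair isolates this change: compound 1 carries the same thiophen-2-yl group but a different ester, so its value of 32% is only a pointer. Compound 3 is expected to rise beyond the scatter, by a number 15 percentage points higher from compound 2 to compound 3 (beyond the scatter). Compound 3 is estimated at 26% in this assay, within 8% to 45%.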

Compound 3, a percentage reported as inhibition, at one concentration (the size of the read-out at that concentration, not a potency): 7%
Estimate against measurement, compound 3: 19 percentage points above; the whole stated range lies above it.
By their numbers in this assay, from the lowest: compounds 3 and 2 (each within the scatter of the next); then compound 1.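

In this assay, thiophen-2-yl in place of furan-3-yl on the saturated ring carbon gives a number 4 percentage points lower from compound 2 to compound 3 (within the scatter), so this change does not separate the two rings when the ester is that of compound 3. The ester chain does separate compounds: methyl in place of hydrogen on the saturated chain carbon bound to oxygen gives a number 25 percentage points lower from compound 1 to compound 3 (beyond the scatter). Nothing available here explains either step. Still open, as far as these compounds go, is whether furan-3-yl would match thiophen-2-yl on the ester of compound 1, and whether a phenyl ring at this position or a longer ester chain would change the reading.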